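Methyl additions around a sulfamoylamino benzamide core

The source may hold more compounds than are shown below. What is called first, only, known or untested is meant among the compounds shown, and "the series" means these compounds.

Compound 1 (`CCN1CCCC1CNC(=O)c1cc(NS(N)(=O)=O)ccc1OC`) is the parent of this small set. In a functional assay on the whole organism for inhibition, with Mus musculus as the target (a lower number here means that less compound is needed, a higher number that more compound is needed for the effect), compound 1 gives > 50 mg/kg, which is a limit of the assay rather than a number. Compound 2 (`CCN1CCCC1CNC(=O)c1cc(NS(N)(=O)=O)c(C)cc1OC`) carries methyl in place of hydrogen on an aromatic carbon. In this assay compound 2 gives > 50 mg/kg, again a limit. The step that the two limits leave unreadable from compound 1 to compound 2 therefore cannot be sized. Compound 3 (`CCN1CCCC1CNC(=O)c1cc(N(C)S(N)(=O)=O)ccc1OC`) differs from compound 1 in its core by methyl in place of hydrogen on a sulfonamide nitrogen. In this assay compound 3 gives > 50 mg/kg, also a limit. The step that the two limits leave unreadable from compound 1 to compound 3 is likewise unreadable. Compound 4 (`CCN1CCCC1CNC(=O)c1cc(N(C)S(N)(=O)=O)c(C)cc1OC`) is not yet measured; it stands to compound 3 as compound 2 stands to compound 1, with methyl in place of hydrogen on an aromatic carbon. This is the same kind of change as from compound 1 to compound 2, though the place differs: there the entering methyl is ortho to a sulfamoylamino group (5 heavy atoms), here it is ortho to a methyl(sulfamoyl)amino group (6 heavy atoms). Among the compounds with values here, the only evidence is the limit of > 50 mg/kg in this assay, at which 3 of the 3 values shown sit, and on that rests the expected step that the limit leaves unreadable from compound 3 to compound 4. For compound 4 in this assay the expected value is 100 mg/kg, between 40 mg/kg and 300 mg/kg, with the assay most likely again reporting only a limit.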

Compound 4, dose for half-maximal effect: > 50 mg/kg
Compound 4: a limit, no number; the forecaster's own chance of this, stated with the estimate: 85%; the middle value is on the limit's open side.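

In this assay compound 4 gives > 50 mg/kg, a limit of the assay. Its steps from compound 3 and from compound 2 therefore cannot be read. The compounds shown leave open what dose compound 1, compound 2, compound 3 or compound 4 would need for the effect, and whether either methyl addition changes that dose: the limit of > 50 mg/kg in this assay, at which 4 of the 4 values shown sit.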